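This account rests on a few compounds, and the source may have more. Where it says the series, first, only, none or still open, it means among the compounds named here.

Measured compounds:
Compound 1 `Cn1cc(-c2cnc3ccc(NC(=O)c4ccc(F)cc4)nc3c2)cn1` – in a functional assay on A549 cells (Homo sapiens) for antiproliferative activity, read by MTT assay, with a stated time of 48 h (a higher number here means a weaker inhibitor, a lower number a stronger inhibitor), compound 1 gives > 50000 nM, which is a limit of the assay.
Compound 2 `COc1ccc(C(=O)Nc2ccc3ncc(-c4cnn(C)c4)cc3n2)cc1` – in this assay compound 2 gives 6400 nM.
Compound 3 `Cn1cc(-c2cnc3ccc(NCc4ccc(F)cc4)nc3c2)cn1` – in this assay compound 3 gives > 50000 nM, again a limit of the assay.

The change from compound 1 to compound 2, (methoxy in place of fluoro on an aromatic carbon), gave an at least 7.8-fold lower number from compound 1 to compound 2 (0.89 log units; beyond the scatter). Compound 3 shares this starting point only in part: how its core differs from the core of compound 1 is not broken down here. Compound 4 `COc1ccc(CNc2ccc3ncc(-c4cnn(C)c4)cc3n2)cc1` carries the same change, (methoxy in place of fluoro on an aromatic carbon). Two of the three values sit at the limit of > 50000 nM in this assay, at which 2 of the 3 values shown sit, so the earlier step is known only as a lower bound. A step of about an at least 2.5-fold lower number from compound 3 to compound 4 (0.39 log units; beyond the scatter) is expected from compound 3 to compound 4, resting on an at least 7.8-fold lower number from compound 1 to compound 2 (0.89 log units; beyond the scatter). For compound 4 a value around 20000 nM is estimated, between 5000 nM and 60000 nM.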

Compound 4, half-maximal inhibitory concentration: > 50000 nM
Compound 4 was reported as a limit; the forecaster's own chance of this, stated with the estimate: 45%; middle value at least 2.5-fold (0.39 log units) from the limit.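

No step from compound 3 to compound 4 can be read, because both are reported only as a limit of the assay: the limit of > 50000 nM in this assay, at which 3 of the 4 values shown sit.

On these data alone, whether methoxy in place of fluoro changes anything on the core of compound 3, as it did on the core of compound 1, stays open.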